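The compounds below may be only part of what the source reports. "The series", "measured", "known", "first", "only" and "open" are said of these compounds alone.

The compounds measured so far in a functional assay on MCF7 cells (Homo sapiens) for antiproliferative activity, read by MTT assay, with a stated time of 72 h (a higher number here means a weaker inhibitor, a lower number a stronger inhibitor), are these:

Compound 1, `COc1cc(-n2cnc3ccc(-c4ccc([N+](=O)[O-])cc4)cc32)cc(OC)c1OC`, gives 740 nM.
Compound 2, `COc1cc(-n2cnc3ccc(-c4ccc(Cl)cc4)cc32)cc(OC)c1OC`, gives 1320 nM.
Compound 3, `COc1cc(-n2cnc3ccc(-c4cc(F)ccc4F)cc32)cc(OC)c1OC`, gives 6420 nM.

Compound 3 stands highest of the three in this assay, and so is the weakest inhibitor of the set: the number rises a 4.9-fold higher number from compound 2 to compound 3 (0.69 log units; beyond the scatter) and an 8.7-fold higher number from compound 1 to compound 3 (0.94 log units; beyond the scatter), both beyond the scatter, whereas a 1.8-fold higher number from compound 1 to compound 2 (0.25 log units; within the scatter) stays within it. Compound 4, `COc1ccccc1-c1ccc2ncn(-c3cc(OC)c(OC)c(OC)c3)c2c1`, differs from compound 3 in one place: 2-methoxyphenyl in place of 2,5-difluorophenyl on an aromatic carbon. Among the measured compounds shown here, no measured compound carries a 2-methoxyphenyl, so nothing shows directly how that group behaves. The two steps that bear on the change, an 8.7-fold higher number from compound 1 to compound 3 (0.94 log units; beyond the scatter) and a 4.9-fold higher number from compound 2 to compound 3 (0.69 log units; beyond the scatter), show that the 2,5-difluorophenyl on this aromatic carbon sits modestly higher than either the 4-nitrophenyl or the 4-chlorophenyl. Leaving the 2,5-difluorophenyl is therefore expected to bring a modest fall in the number, though with wide uncertainty. Relative to compound 3, the step for compound 4 is expected to be a 2.1-fold lower number from compound 3 to compound 4 (0.33 log units; beyond the scatter). The estimate for compound 4 in this assay is 3000 nM, with a range from 800 nM to 11000 nM.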

Compound 4, half-maximal inhibitory concentration: 1750 nM
Estimate against measurement, compound 4: 1.7-fold (0.23 log units) above; the measured number falls inside the stated range.
By their numbers in this assay, from the lowest: compounds 1, 2 and 4 (each within the scatter of the next, the first and the last beyond it); then compound 3.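

In this assay, the 2-methoxyphenyl shows that the high number of compound 3 is not shared by every group at this position that carries a substituent in its 2-position (a 3.7-fold lower number from compound 3 to compound 4 (0.56 log units; beyond the scatter)). The number for this group cannot be told apart from that for the 4-chlorophenyl (a 1.3-fold higher number from compound 2 to compound 4 (0.12 log units; within the scatter)), so among these compounds a group in the 4-position of the ring is not needed to reach that level. The 4-nitrophenyl of compound 1 still gives a lower number (a 2.4-fold higher number from compound 1 to compound 4 (0.37 log units; beyond the scatter)).

Nothing measured here explains why these groups differ. As far as these compounds go, it also remains open whether a 4-methoxyphenyl or a 2-aminophenyl on the same aromatic carbon would fall nearer compound 1 or compound 3.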